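The source may report more compounds than this note shows. Statements on the series, on what has been measured and on what is new or still open speak of the compounds shown alone.

Working notes on the selenium series, all read in a functional assay on Jurkat cells (Homo sapiens) for cytotoxicity, read by MTT assay, with a stated time of 24 h; a lower number here means that less compound is needed, a higher number that more compound is needed for the effect. Compound 1 `CCOC(=O)c1cc([Se]Cc2ccccc2)c2cc(OC)ccc2n1`, with benzyl on the selenium, gives 20800 nM. Compound 2 `CCOC(=O)c1cc([Se]c2ccc(F)cc2)c2cc(OC)ccc2n1`, with 4-fluorophenyl there, gives 134000 nM. Compound 3 `CCOC(=O)c1cc([Se]c2ccccc2)c2cc(OC)ccc2n1`, with phenyl there, gives 102000 nM. Compound 3 therefore stands level with compound 2 within the scatter, and apart from the benzyl analogue: a 4.9-fold higher number from compound 1 to compound 3 (0.69 log units; beyond the scatter).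

Next is compound 4 `CCOC(=O)c1cc([Se]c2ccc(OC)cc2)c2cc(OC)ccc2n1`, which differs from compound 3 by methoxy in place of hydrogen on an aromatic carbon, para to a large group, or phenyl to 4-methoxyphenyl.

Within the data shown here, the closest precedent is the only measured change on that same phenyl, hydrogen in place of fluoro: a 1.3-fold lower number from compound 2 to compound 3 (0.12 log units; within the scatter), within the scatter. The larger steps, a 6.4-fold higher number from compound 1 to compound 2 (0.81 log units; beyond the scatter) and a 4.9-fold higher number from compound 1 to compound 3 (0.69 log units; beyond the scatter), both replace benzyl, a change compound 4 does not make. Among the measured compounds shown here, no methoxy analogue has been measured, so this single precedent carries the expectation, and it is thin.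

No step beyond the scatter is expected in this assay. The expected step is a 1.0-fold lower number from compound 3 to compound 4 (0.01 log units; within the scatter). For compound 4 the estimated value is 100000 nM, with an expected range of 50000 nM to 200000 nM.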

Compound 4, half-maximal effective concentration: 82500 nM
Compound 4: the middle estimate sits 1.2-fold (0.08 log units) above what was measured, within the range that was stated.
By their numbers in this assay, from the lowest: compound 1; then compounds 4, 3 and 2 (each within the scatter of the next).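

The series now has a second substituent at this place on the phenyl ring, and methoxy on that aromatic carbon, para to a large group, leaves the number in this assay where it stood with hydrogen (a 1.2-fold lower number from compound 3 to compound 4 (0.09 log units; within the scatter)). Methoxy in place of fluoro gives the same reading (a 1.6-fold lower number from compound 2 to compound 4 (0.21 log units; within the scatter)), so hydrogen, fluoro and methoxy at this place are not told apart by this assay, and the earlier fluoro step no longer stands alone. The gap to the benzyl analogue survives this third aryl group (a 4.0-fold higher number from compound 1 to compound 4 (0.60 log units; beyond the scatter)), so among the four compounds the change of group on the selenium moves the number, while the change on the phenyl does not, and no data here explain either observation.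

The compounds shown leave open whether an amine or a carboxylic acid on that same aromatic carbon would also stay level with hydrogen, fluoro and methoxy. They also leave open whether a longer chain on the selenium, such as phenylethyl, would hold or widen the separation seen with benzyl in this assay.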